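Thiophene Replaces Methylpiperazine on the Benzyl Ring

The compounds below may be only part of what the source reports. "The series", "measured", "known", "first", "only" and "open" are said of these compounds alone.

Three ureas that share a cycloheptyl group on the urea nitrogen have been tested in a functional assay on a cell-free system (plasma) with sterol O-acyltransferase, Soat (Rattus norvegicus) as the target; on this read-out higher numbers stand for an effect only at larger amounts of compound and lower numbers for an effect already at smaller amounts. Compound 1 `O=C(Nc1c(F)cc(F)cc1F)N(Cc1ccc(-c2cccs2)cc1)C1CCCCCC1` carries a trifluorophenyl urea and a thiophen-2-yl on the benzyl ring; in this assay compound 1 reaches only a limit, > 1 mg/kg. Compound 2 `Cc1cc(C)c(NC(=O)N(Cc2ccc(-c3n[nH]c(C)n3)cc2)C2CCCCCC2)c(C)c1` has a trimethylphenyl urea and a 5-methyl-1H-1,2,4-triazol-3-yl; in this assay compound 2 also stops at a limit, > 1 mg/kg. Compound 3 `Cc1cc(C)c(NC(=O)N(Cc2ccc(N3CCN(C)CC3)cc2)C2CCCCCC2)c(C)c1` keeps the trimethylphenyl urea and carries a 4-methylpiperazin-1-yl; in this assay compound 3 likewise gives only a limit, > 1 mg/kg. The step that the two limits leave unreadable from compound 2 to compound 3 therefore cannot be read because of the limit of > 1 mg/kg in this assay, at which 3 of the 3 values shown sit.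

Compound 4 `Cc1cc(C)c(NC(=O)N(Cc2ccc(-c3cccs3)cc2)C2CCCCCC2)c(C)c1` differs from compound 3 in one place: thiophen-2-yl in place of 4-methylpiperazin-1-yl on an aromatic carbon. Going by the values given here, compound 1 already carries the same thiophen-2-yl and sits at the limit > 1 mg/kg, so no measured step around this change is readable. Compound 4 is therefore expected to show no readable step, a step that the limit leaves unreadable from compound 3 to compound 4, and most likely to stop at the limit as well. The estimate for compound 4 is 2 mg/kg with a range from 0.7 mg/kg to 10 mg/kg.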

Compound 4, dose for half-maximal effect: 0.28 mg/kg
Compound 4: middle estimate off by 7.1-fold (0.85 log units), on the high side; measured number outside the range, below it.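

In this assay, a thiophen-2-yl on this aromatic carbon, para to a large group, turns a limit into a real number when the urea carries the 2,4,6-trimethylphenyl: the exchange for the 4-methylpiperazin-1-yl gives an at least 3.5-fold lower number from compound 3 to compound 4 (0.55 log units; beyond the scatter), and the exchange for the 5-methyl-1H-1,2,4-triazol-3-yl gives an at least 3.5-fold lower number from compound 2 to compound 4 (0.55 log units; beyond the scatter). The thiophen-2-yl is not enough on its own, for with that group kept, the change at the other end of the molecule gives an at least 3.5-fold lower number from compound 1 to compound 4 (0.55 log units; beyond the scatter), so among these four compounds only the pairing of thiophen-2-yl with 2,4,6-trimethylphenyl leaves the limit. All three steps are minimum sizes, and the true gaps may be larger, because each starting compound carries a limit and not an exact number: the limit of > 1 mg/kg in this assay, at which 3 of the 4 values shown sit.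

The compounds shown leave open whether the sulfur-containing ring itself matters at this position, which a phenyl, a furan-2-yl or a thiophen-3-yl in its place would help to settle. They also leave open how narrowly the urea end is defined, since only 2,4,6-trimethylphenyl and 2,4,6-trifluorophenyl appear there, and a 2,4,6-trichlorophenyl or a 2,6-dimethylphenyl would test that.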